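The compounds below may be only part of what the source reports. "The series", "measured", "known", "first", "only" and "open" are said of these compounds alone.

Measured in a functional assay on MCF7 cells (Homo sapiens) for inhibition, read by MTT assay, with a stated time of 72 h; on this read-out lower numbers stand for stronger inhibition and higher numbers for weaker inhibition:
- compound 1 `Cc1cc(Nc2cc(-c3ccccc3)[nH]n2)n2nc(SCc3c(Cl)cccc3Cl)nc2n1`: 3230 nM
- compound 2 `Cc1cc(Nc2cc(-c3ccccc3)[nH]n2)n2nc(SCc3cccc(Br)c3)nc2n1`: 5140 nM
- compound 3 `Cc1cc(Nc2cc(-c3ccccc3)[nH]n2)n2nc(SCc3ccc(C(F)(F)F)cc3)nc2n1`: 4820 nM

The three values lie within the scatter of one another, and compound 3 at 4820 nM cannot be separated from either neighbour. The steps reaching it are a 1.1-fold lower number from compound 2 to compound 3 (0.03 log units; within the scatter) and a 1.5-fold higher number from compound 1 to compound 3 (0.17 log units; within the scatter). The remaining step is a 1.6-fold higher number from compound 1 to compound 2 (0.20 log units; within the scatter).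

The next change leads to compound 4 `Cc1cc(Nc2cc(-c3ccccc3)[nH]n2)n2nc(SCc3csc4ccccc34)nc2n1`: 1-benzothiophen-3-yl in place of 4-(trifluoromethyl)phenyl on a saturated chain carbon bound to a sulfur, (1-benzothiophen-3-yl in place of 4-(trifluoromethyl)phenyl on a saturated chain carbon bound to a sulfur). For the measured compounds named here, all the measured steps bear on it, since each exchanges one aromatic group for another at this same place, and none goes beyond the scatter. None of the measured compounds carries a five-membered aromatic ring here, so the data do not test that feature, and the range is kept wide for this reason.

In this assay, no step beyond the scatter is expected, and no direction can be assigned. The expected step is a 1.1-fold lower number from compound 3 to compound 4 (0.05 log units; within the scatter). For compound 4 the estimated value is 4300 nM, with an expected range from 2400 nM to 7700 nM.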

Compound 4, half-maximal inhibitory concentration: 3470 nM
Estimate against measurement, compound 4: 1.2-fold (0.09 log units) above; the measured number falls inside the stated range.
By their numbers in this assay, from the lowest: compounds 1, 4, 3 and 2 (each within the scatter of the next).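

In this assay, for the compounds shown here, 1-benzothiophen-3-yl is the first group at this place, on a saturated chain carbon bound to a sulfur, to bring a five-membered aromatic ring with a hetero atom, and the steps to it are a 1.4-fold lower number from compound 3 to compound 4 (0.14 log units; within the scatter), a 1.5-fold lower number from compound 2 to compound 4 (0.17 log units; within the scatter) and a 1.1-fold higher number from compound 1 to compound 4 (0.03 log units; within the scatter). A group with two aromatic rings therefore cannot be separated from the three groups with one aromatic ring, so the four compounds form a single flat set on this read-out, with no order among them. Nothing available accounts for this flat picture, so it stays a plain observation.

From the compounds shown here alone, all four compounds carry an aromatic group at this place, so it remains open whether an amine or a carboxylic acid there would give a step beyond the scatter. Equally open, going by these compounds, are a longer chain between the sulfur and the aromatic ring and any exchange of the phenyl group elsewhere on the shared core, either of which could show whether the number in this assay can move at all.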